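The compounds below may be only part of what the source reports. "The series", "measured", "known", "first", "only" and "open" are said of these compounds alone.

Measured compounds:
compound 1 `CCCOc1ccc(C(=O)/C=C/c2ccc(C(=O)Nc3cccc(-c4cc(C(=O)OC)no4)c3)cc2)cc1`: > 40 ug/mL
compound 2 `CCOC(=O)c1nnn(-c2cccc(NC(=O)c3ccc(/C=C/C(=O)c4ccc(Cl)cc4)cc3)c2)c1C`: "not determined" (no result reported)
compound 3 `CCCOc1ccc(C(=O)/C=C/c2ccc(C(=O)O)cc2)cc1`: < 10 ug/mL

All three were run in an ADME assay on Vero cells (Chlorocebus sabaeus) for cytotoxicity, read by MTT assay, with a stated time of 72 h; on this read-out lower numbers stand for higher toxicity in this test and higher numbers for lower toxicity in this test. For compound 1 the result is only a limit, > 40 ug/mL, the edge of what this assay reports rather than a number. Compound 2 has no result in this assay, "not determined" (no result reported). For compound 3 the result is likewise a limit, < 10 ug/mL. Going by the values given here, compound 1 therefore stands at the limit of > 40 ug/mL in this assay, at which 1 of the 3 values shown sits, and compound 3 stands at the limit of < 10 ug/mL in this assay, at which 1 of the 3 values shown sits; since neither is a single number, no measured step between them can be counted, and no compound here has a plain value.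

The unmeasured compound 4 `COC(=O)c1cc(-c2cccc(NC(=O)c3ccc(/C=C/C(=O)c4ccccc4C)cc3)c2)on1` differs from compound 1 in one place: 2-methylphenyl in place of 4-propoxyphenyl on a carbonyl carbon. The rest of the shared core of compound 1 stays as it is. Among the compounds with values here, no step between two measured compounds of this kind is available to gauge the effect, so the expectation rests on compound 1 alone, and a change of no size beyond the scatter is expected. Compound 4 is expected to give 45 ug/mL, between 20 ug/mL and 90 ug/mL, most likely again reported only as a limit. The step this estimate means, a step that the limit leaves unreadable from compound 1 to compound 4, is expected to stay within the scatter.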

Compound 4, half-maximal cytotoxic concentration: > 25 ug/mL
Compound 4: no number, only a limit; the forecaster's own chance of this, stated with the estimate: 70%; the middle value does not contradict the limit.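

Compound 1 and compound 4 are each reported only as a limit in this assay and not as a number, and the step between them cannot be read. Left open is whether 2-methylphenyl in place of 4-propoxyphenyl on a carbonyl carbon changes toxicity in this test at all, and by how much.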